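A few compounds are considered here, and "the series" means these few. Any claim that something is new, unique, unknown or untested is made for them only; others in the source may bear on it.

Compound 3 `COc1cc2c(Nc3ccc(C#N)cc3)ncnc2cc1OCCCN1CCCCC1CCO` is one of three measured compounds sharing a core. In a functional assay on MCF7 cells (Homo sapiens) for antiproliferative activity, read by MTT assay, with a stated time of 72 h (on this read-out higher numbers stand for weaker inhibition and lower numbers for stronger inhibition), compound 3 gives > 100000 nM, which is a limit of the assay and not a number. Compound 1 `CCN(CC)CCCOc1cc2ncnc(Nc3ccc(C#N)cc3)c2cc1OC` gives in this assay > 100000 nM, again a limit of the assay. For the measured compounds named here, compound 2 `COc1cc2c(Nc3ccc(C#N)cc3)ncnc2cc1OCCCN1CCC(C)CC1` gives in this assay 43100 nM, the only value here that is a number. Two of the three values thus sit at the limit of > 100000 nM in this assay, at which 2 of the 3 values shown sit, so compound 3 stands at the weak end of what can be seen, with no number of its own.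

Compound 4 `COc1cc2c(Nc3ccc(C#N)cc3)ncnc2cc1OCCCN1CCN(C)CC1` differs from compound 3 in one place: 4-methylpiperazin-1-yl in place of 2-(2-hydroxyethyl)piperidin-1-yl on a saturated chain carbon, three bonds along the chain from an oxygen on an aromatic ring. The step that bears most directly on this is an at least 2.3-fold higher number from compound 2 to compound 3 (0.36 log units; beyond the scatter), where the 2-(2-hydroxyethyl)piperidin-1-yl entered and the number rose; an at least 2.3-fold lower number from compound 1 to compound 2 (0.36 log units; beyond the scatter) shows that a six-membered ring amine without the hydroxyethyl arm can lower the number; a step that the two limits leave unreadable from compound 1 to compound 3 stays unreadable. Removing the 2-(2-hydroxyethyl)piperidin-1-yl in favour of 4-methylpiperazin-1-yl is therefore expected to reverse the rise, giving an at least 2.5-fold lower number from compound 3 to compound 4 (0.39 log units; beyond the scatter) in this assay, a modest drop from the limit. Compound 4 is estimated at 40000 nM, between 10000 nM and 120000 nM, with a fair chance that only a limit is again reported.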

Compound 4, half-maximal inhibitory concentration: 71100 nM
Compound 4: the middle estimate sits 1.8-fold (0.25 log units) below what was measured, and the stated range covers the measured number.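

In this assay, compound 4 shows that a second six-membered ring amine on the saturated chain carbon, three bonds along the chain from an oxygen on an aromatic ring, can give a readable number. Exchanging 4-methylpiperidin-1-yl for 4-methylpiperazin-1-yl gives a 1.6-fold higher number from compound 2 to compound 4 (0.22 log units; within the scatter), so the two ring amines cannot be told apart in this assay, and the number of compound 2 is not tied to 4-methylpiperidin-1-yl alone. Against the compounds held at a limit, the change gives an at least 1.4-fold lower number from compound 3 to compound 4 (0.14 log units; that floor lies within the scatter) and an at least 1.4-fold lower number from compound 1 to compound 4 (0.14 log units; that floor lies within the scatter); both floors lie within the scatter, so neither diethylamino nor 2-(2-hydroxyethyl)piperidin-1-yl is shown to differ from 4-methylpiperazin-1-yl.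

Compound 1 and compound 3 have no numbers of their own, and the step between them cannot be read: the limit of > 100000 nM in this assay, at which 2 of the 4 values shown sit.

Going by these compounds, whether a morpholine, an open-chain amine carrying a hydroxyl group, or a longer chain at this place would move the number clearly away from those of compound 2 and compound 4 stays open.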